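This account rests on a few compounds, and the source may have more. Where it says the series, first, only, none or still open, it means among the compounds named here.

Compound 1, `O=[N+]([O-])c1cccc(CSc2nnc(-c3ccc4c(c3)OCCO4)o2)c1`: in a functional assay on HepG2 cells (Homo sapiens) for antiproliferative activity, read by MTT assay, with a stated time of 48 h (a lower number here means a stronger inhibitor, a higher number a weaker inhibitor), compound 1 gives 38300 nM.
Compound 2, `Fc1ccccc1CSc1nnc(-c2ccc3c(c2)OCCO3)o1`: in this assay compound 2 gives 24000 nM.
Compound 3, `c1ccc(CSc2nnc(-c3ccc4c(c3)OCCO4)o2)cc1`: in this assay compound 3 gives 32100 nM.

Compound 3 stands second highest of the three numbers. Its nearest neighbour is compound 1, with a 1.2-fold lower number from compound 1 to compound 3 (0.08 log units; within the scatter); its furthest is compound 2, with a 1.3-fold higher number from compound 2 to compound 3 (0.13 log units; within the scatter). Both steps lie within the scatter, so the three measured compounds cannot be told apart on these numbers.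

Compound 4, `O=[N+]([O-])c1ccc(CSc2nnc(-c3ccc4c(c3)OCCO4)o2)cc1`, differs from compound 3 by nitro in place of hydrogen on an aromatic carbon. Going by the values given here, the step that bears on it is the one from compound 1 to compound 3, in which a nitro group left an aromatic carbon of the same ring and gave a 1.2-fold lower number from compound 1 to compound 3 (0.08 log units; within the scatter), within the scatter. The fluoro step, a 1.3-fold higher number from compound 2 to compound 3 (0.13 log units; within the scatter), was likewise within the scatter. Among the compounds with values here, nothing among the measured compounds indicates that a nitro group on this ring moves the number beyond the scatter, so for compound 4 no step beyond the scatter is expected: a 1.1-fold higher number from compound 3 to compound 4 (0.04 log units; within the scatter). Compound 4 is therefore estimated at 35000 nM, with a range from 15000 nM to 80000 nM.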

Compound 4, half-maximal inhibitory concentration: 35400 nM
Compound 4: middle estimate off by 1.0-fold (0.00 log units), on the low side, within the range that was stated.
By their numbers in this assay, from the lowest: compounds 2, 3, 4 and 1 (each within the scatter of the next).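

In this assay, nitro in place of hydrogen on an aromatic carbon, para to a large group, gives a 1.1-fold higher number from compound 3 to compound 4 (0.04 log units; within the scatter), so this position also shows no step beyond the scatter for this change. The nitro group thus stands at a second place on the ring, and compound 1 at 38300 nM and compound 4 at 35400 nM lie within the scatter of each other, so these two placements cannot be told apart here. No measurement bearing on the reason for this result is available.

As far as these compounds go, whether an amine, a carboxylic acid or a longer chain at this position would move the number beyond the scatter stays open. Also open, from the compounds shown here alone, is whether any change to the shared core would do so, as all four compounds keep that core and lie close together.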